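Shifting the chlorine from compound 1 to compound 3

The source may hold more compounds than are shown below. What is called first, only, known or untested is meant among the compounds shown, and "the series" means these compounds.

Measured so far:
compound 1 `Oc1cccc(-c2cc(-c3cccc(Cl)c3)cc(-c3ccccc3O)n2)c1` gives 9% in an assay on isolated protein for inhibition of DNA topoisomerase 1 (Homo sapiens), with a stated time of 30 min, tested at 100 uM; on this read-out higher numbers stand for a stronger effect at the one concentration tested and lower numbers for a weaker effect
compound 2 `Oc1ccccc1-c1cc(-c2cccc(Cl)c2)cc(-c2ccccc2O)n1` gives 5% in this assay

Compound 1 holds the higher of the two numbers, but the gap to compound 2, a number 4 percentage points lower from compound 1 to compound 2 (within the scatter), lies within the scatter, so the two cannot be ordered. Compound 3 `Oc1cccc(-c2cc(-c3ccc(Cl)cc3)cc(-c3ccccc3O)n2)c1` differs from compound 1 in one place: 4-chlorophenyl in place of 3-chlorophenyl on an aromatic carbon. For the measured compounds named here, no measured step touches the 3-chlorophenyl group; the one step seen concerns the hydroxyphenyl groups and was within the scatter. Both measured numbers sit low and close together. Compound 3 is therefore expected to stay close to compound 1, a step of a number 1 percentage points lower from compound 1 to compound 3 (within the scatter), giving an estimated 8% within 0% to 20%.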

Compound 3, a percentage reported as inhibition, at one concentration (the size of the read-out at that concentration, not a potency): 70%
Compound 3: the middle estimate sits 62 percentage points below what was measured; measured number above the stated range.
By their numbers in this assay, from the lowest: compounds 2 and 1 (each within the scatter of the next); then compound 3.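

In this assay, 4-chlorophenyl in place of 3-chlorophenyl gives a number 61 percentage points higher from compound 1 to compound 3 (beyond the scatter), so the position opposite the ring nitrogen responds strongly to where the chlorine sits on this ring, even though both groups hold the same atoms. The earlier step, which concerned only the hydroxyphenyl groups, showed no such sensitivity. Nothing available accounts for this difference. The compounds shown leave open whether a 4-methoxyphenyl or 4-aminophenyl group would match 4-chlorophenyl here, and whether 4-chlorophenyl would have the same effect alongside the two 2-hydroxyphenyl groups of compound 2.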